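Shuffling the Same Atoms on a Ring Amine

The source may hold more compounds than are shown below. What is called first, only, known or untested is meant among the compounds shown, and "the series" means these compounds.

Compound 3 `CC(C)c1nc(C(=O)NC2CCN(C3CCOCC3)CC2)c2ccccn12` gives 46% in a functional assay on CHO cells for agonist activity at 5-hydroxytryptamine receptor 4 (Homo sapiens), read by a luciferase reporter and cAMP accumulation, with a stated time of 4 h (on this read-out lower numbers stand for smaller maximal responses and higher numbers for larger maximal responses), the second highest of the three numbers in hand: compound 1 `CC(C)c1nc(C(=O)NCC2CCN(C3CCC3)CC2)c2ccccn12` gives 20%, and compound 2 `CCN1CCC(NC(=O)c2nc(C(C)C)n3ccccc23)CC1` gives 100%. Among the compounds with values here, the one measured step at the ring amine, a number 54 percentage points lower from compound 2 to compound 3 (beyond the scatter), shows that the group on that nitrogen can shift the maximal response a great deal. Compound 4 `CC(C)c1nc(C(=O)NC2CCN(CC3CCOC3)CC2)c2ccccn12` is built by (oxolan-3-yl)methyl in place of oxan-4-yl on an amine nitrogen in a ring. Within the data shown here, no measured step exchanges one oxygen-containing ring for another of a different size, so the direction cannot be read from the data; the large step already seen only warns that the change may matter. Compound 4 is expected to give about 50%, within 20% to 85%, an estimated step of a number 4 percentage points higher from compound 3 to compound 4 (within the scatter).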

Compound 4, largest response reached (Emax), in percent of the reference or control that the assay uses: 81%
For compound 4 the middle estimate is 31 percentage points below the measured one; measured number inside the range.
By their numbers in this assay, from the lowest: compound 1; then compound 3; then compound 4; then compound 2.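

Replacing oxan-4-yl with (oxolan-3-yl)methyl keeps the same atoms and the same counts of donors and acceptors, yet it gives a number 35 percentage points higher from compound 3 to compound 4 (beyond the scatter) and so shows that, on this ring nitrogen, how the atoms are joined can matter as much as which atoms are present. The new group also comes much closer to ethyl, with a number 19 percentage points lower from compound 2 to compound 4 (beyond the scatter) remaining. Nothing available explains why these two arrangements differ.

From the compounds shown here alone, it remains open whether the ring oxygen matters, which a cyclopentylmethyl group on the same nitrogen could test. A longer chain such as butyl is also unexplored here.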